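Cytotoxicity notes on a thiazolyl ketone series

The compounds below may be only part of what the source reports. "The series", "measured", "known", "first", "only" and "open" are said of these compounds alone.

Measured compounds:
compound 1 `COc1ccc(-c2nc(C)c(C(=O)CSc3nc(-c4ccc(Cl)cc4)c(C#N)c(=O)[nH]3)s2)cc1`: 63000 nM
compound 2 `COc1ccc(-c2nc(C)c(C(=O)CSc3nc(-c4ccc(Cl)c(Cl)c4)c(C#N)c(=O)[nH]3)s2)cc1`: 45600 nM
compound 3 `Cc1nc(-c2ccccc2)sc1C(=O)CSc1nc(-c2ccc(Cl)cc2)c(C#N)c(=O)[nH]1`: "not determined" (no result reported)

In an ADME assay on HEK293 cells (Homo sapiens) for cytotoxicity, read by MTT assay, with a stated time of 48 h (a higher number here means a weaker inhibitor, a lower number a stronger inhibitor), compound 1 gives 63000 nM and compound 2 gives 45600 nM. The two differ by chloro in place of hydrogen on an aromatic carbon, and the step is a 1.4-fold lower number from compound 1 to compound 2 (0.14 log units; within the scatter), so the two values are indistinguishable here.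

Compound 3 `Cc1nc(-c2ccccc2)sc1C(=O)CSc1nc(-c2ccc(Cl)cc2)c(C#N)c(=O)[nH]1` carries a different core; it differs from compound 1 by hydrogen in place of methoxy on an aromatic carbon. For compound 3 the entry in this assay reads "not determined" (no result reported), so the second pair has no anchor of its own.

Compound 4 `Cc1nc(-c2ccc(Cl)cc2)sc1C(=O)CSc1nc(-c2ccc(Cl)cc2)c(C#N)c(=O)[nH]1` differs from compound 3 by chloro in place of hydrogen on an aromatic carbon. Among the compounds with values here, this is the same kind of change as the one from compound 1 to compound 2, but not the same: in the earlier pair the entering chloro sits ortho to a chloro group and meta to a large group, whereas in compound 4 it sits para to a large group, on a ring that otherwise bears only hydrogen.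

For compound 4 in this assay the step from compound 3 is expected to be small, resting on the step from compound 1 to compound 2 being within the scatter. Since compound 3 itself has no value, the expectation for compound 4 leans on compound 1 and compound 2 and is given broadly: compound 4 is estimated at 55000 nM, expected to fall between 20000 nM and 150000 nM.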

Compound 4, half-maximal inhibitory concentration: 75100 nM
Compound 4: middle estimate off by 1.4-fold (0.14 log units), on the low side; measured number inside the range.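

In this assay, chloro in place of methoxy on an aromatic carbon gives a 1.2-fold higher number from compound 1 to compound 4 (0.08 log units; within the scatter) and so leaves the number unchanged within the scatter, just as chloro in place of hydrogen gives a 1.4-fold lower number from compound 1 to compound 2 (0.14 log units; within the scatter) on the core of compound 1. Within the data shown here, this shows only that compound 4, with phenyl changed to 4-chlorophenyl, stays in the same range as compound 1; it does not show that the change from hydrogen to chloro transfers from one core to the other, and the step from compound 3 to compound 4 cannot be read, with no number for compound 3 to start from. No supporting measurement bears on the cause of these results.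

The compounds shown cover only methoxy and chloro on that outer ring and a single added chloro on the other aryl ring, so an amine, a carboxylic acid or a longer alkoxy chain such as butoxy at the same place remains open. Also open, as far as these compounds go, is whether replacing the nitrile with a carboxylic acid, or the methyl on the core with a longer chain, would move the number beyond the scatter in this assay at all.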